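A few compounds are considered here, and "the series" means these few. Any claim that something is new, unique, unknown or untested is made for them only; others in the source may bear on it.

Compound 2 `COc1ccc(/C=N/NC(=O)Nc2ccc(Oc3ccnc(-c4nncn4CCN(C)C)c3)c(F)c2)c(OC)c1OC` gives 6680 nM in a functional assay on A549 cells (Homo sapiens) for cytotoxicity, read by MTT assay, with a stated time of 72 h (a lower number here means a stronger inhibitor, a higher number a weaker inhibitor), the highest of the two numbers shown. Its nearest companion is compound 1 `CN(C)CCn1cnnc1-c1cc(Oc2ccc(NC(=O)N/N=C/c3ccc(O)c(Br)c3)cc2F)ccn1`, which in this assay gives 1370 nM. Within the data shown here, the single measured step between them, a 4.9-fold higher number from compound 1 to compound 2 (0.69 log units; beyond the scatter), exchanges the group on the carbon with a double bond to nitrogen and moves the number beyond the scatter by a modest amount. Compound 3 `CN(C)CCn1cnnc1-c1cc(Oc2ccc(NC(=O)N/N=C/c3ccccc3)cc2F)ccn1` continues at the same place: it differs from compound 2 by phenyl in place of 2,3,4-trimethoxyphenyl on a carbon with a double bond to nitrogen. Among the measured compounds shown here, no measured step carries the change to an unsubstituted phenyl, so the only guide is the one measured step, which shows that the group at this position can shift the number in this assay by a modest amount in either direction. A step of similar size, most likely back toward the lower number of compound 1, is therefore anticipated, and the expected step is a 1.9-fold lower number from compound 2 to compound 3 (0.28 log units; within the scatter). Compound 3 is estimated at 3500 nM in this assay, with a range from 1200 nM to 10000 nM.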

Compound 3, half-maximal inhibitory concentration: 1860 nM
For compound 3 the middle estimate is 1.9-fold (0.27 log units) above the measured one; low and high end bracket the measured number.
By their numbers in this assay, from the lowest: compounds 1 and 3 (each within the scatter of the next); then compound 2.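

In this assay the unsubstituted phenyl reverses the earlier shift, with a 3.6-fold lower number from compound 2 to compound 3 (0.56 log units; beyond the scatter) as the phenyl takes the place of 2,3,4-trimethoxyphenyl on the carbon with a double bond to nitrogen. The second comparison, a 1.4-fold higher number from compound 1 to compound 3 (0.13 log units; within the scatter) and within the scatter, does not separate phenyl from 3-bromo-4-hydroxyphenyl, so the bromine and hydroxyl of compound 1 are not needed to reach this level, and among the three compounds only the 2,3,4-trimethoxyphenyl of compound 2 stands apart. No supporting measurement is available to explain why this group differs from the other two.

The compounds shown leave open whether all three methoxy groups of compound 2 are needed for the higher number or whether a single methoxy group on the phenyl would already give it. They also leave open whether an amine or a carboxylic acid on the phenyl would move the number in this cell assay at all, since the two substituted rings shown here give no general rule for this place.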